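Cutting the 2-hydroxyethyl chain back to methyl

The source may hold more compounds than are shown below. What is called first, only, known or untested is meant among the compounds shown, and "the series" means these compounds.

Three compounds carry results so far in a functional assay on NCI-H460 cells (Homo sapiens) for cytotoxicity, read by sulforhodamine B assay, with a stated time of 3 days (a lower number here means a stronger inhibitor, a higher number a weaker inhibitor), and the picture is sharply split. Compound 1 (`O=Cc1cn(Cc2ccc(Br)c(Br)c2)c2ccccc12`) gives 63 nM in this read-out. Compound 2 (`Cc1ccc(Cn2cc(CO)c3ccccc32)cc1`) gives 31 nM in the same read-out.

Compound 3 (`OCCc1cn(Cc2ccc(Cl)cc2)c2ccccc12`) is reported as > 31600 nM and that entry is a limit of the assay, not a number. Compound 3 is the only one of its kind here (the limit of > 31600 nM in this assay, at which 1 of the 3 values shown sits).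

Compound 4 (`Cc1cn(Cc2ccc(Cl)cc2)c2ccccc12`) differs from compound 3 only in its side chain, which goes from 2-hydroxyethyl to methyl: hydrogen in place of hydroxymethyl on a saturated chain carbon bound to an aromatic carbon.

Within the data shown here, no measured pair shows this change, so the expectation rests on the single compounds. Compound 2 at 31 nM carries a hydroxyl that compound 4 lacks, and compound 1 at 63 nM carries an aldehyde that compound 4 also lacks. In this assay no step beyond the scatter is therefore expected, and any movement would be towards a lower number. The expected at least 1.0-fold lower number from compound 3 to compound 4 (0.02 log units; that floor lies within the scatter) stays within the scatter, and a report of only a limit is likely. Compound 4 is estimated at 30000 nM with 5000 nM to 50000 nM as the expected range.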

Compound 4, half-maximal inhibitory concentration: > 31600 nM
Compound 4 gave a limit, no number; the forecaster's own chance of this, stated with the estimate: 65%; middle value at least 1.0-fold (0.02 log units) from the limit.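

Among these compounds, compound 3 and compound 4 both stand at a limit of the assay rather than at a number, so no step from 2-hydroxyethyl to methyl can be read between them. The compounds shown leave open whether this side-chain change would move the read-out in a compound that gives a measurable number.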